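Swapping a Dimethylfuran for a Methoxyphenyl Group

The source may hold more compounds than are shown below. What is called first, only, known or untested is meant among the compounds shown, and "the series" means these compounds.

In a functional assay on HCT-116 cells (Homo sapiens) for antiproliferative activity, read by resazurin assay, with a stated time of 5 days (a lower number here means a stronger inhibitor, a higher number a weaker inhibitor), compound 1 (`O=C(NO)c1cc2ccc(CN3CCc4ccccc4C3)c(F)c2s1`) gives 3000 nM. Compound 2 (`Cc1ncoc1C(=O)NCc1ccc2cc(C(=O)NO)sc2c1F`) gives 210 nM. Compound 3 (`Cc1cc(C(=O)NCc2ccc3cc(C(=O)NO)sc3c2F)oc1C`) gives 470 nM, the middle of the three numbers: it is weaker than compound 2 and stronger than compound 1, with both gaps beyond the usual scatter of repeated measurements.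

Compound 4 (`COc1ccc(C(=O)NCc2ccc3cc(C(=O)NO)sc3c2F)cc1`) has not yet been measured. It differs from compound 3 in a single place, with 4-methoxyphenyl in place of 4,5-dimethylfuran-2-yl on a carbonyl carbon.

Within the data shown here, only one measured step bears on this change. With 4,5-dimethylfuran-2-yl in place of 4-methyl-1,3-oxazol-5-yl at that same carbonyl carbon, the result was a 2.2-fold higher number from compound 2 to compound 3 (0.35 log units; beyond the scatter), a modest change. Among the measured compounds shown here, compound 1 has no such carbonyl group and offers no comparable step. For the measured compounds named here, this single example suggests that exchanges here need not move the number far, but no measured compound carries a six-membered ring at this place, and the data give no clear direction. No step beyond the scatter is therefore expected in this assay.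

The estimated change is a 1.2-fold lower number from compound 3 to compound 4 (0.07 log units; within the scatter). For compound 4 the estimated value is 400 nM, with an expected range from 150 nM to 1000 nM.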

Compound 4, half-maximal inhibitory concentration: 50 nM
Compound 4: the middle estimate sits 8.0-fold (0.90 log units) above what was measured; measured number outside the range, below it.
By their numbers in this assay, from the lowest: compound 4; then compound 2; then compound 3; then compound 1.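

In this assay, among these compounds, the group on this carbonyl carbon turns out to matter far more than the single earlier exchange suggested: the earlier swap between two five-membered aromatic rings gave a 2.2-fold higher number from compound 2 to compound 3 (0.35 log units; beyond the scatter), whereas 4-methoxyphenyl in place of 4,5-dimethylfuran-2-yl gives a 9.4-fold lower number from compound 3 to compound 4 (0.97 log units; beyond the scatter). The gain also holds against the other five-membered ring, with 4-methoxyphenyl in place of 4-methyl-1,3-oxazol-5-yl giving a 4.2-fold lower number from compound 2 to compound 4 (0.62 log units; beyond the scatter), so among these three amides the one carrying a six-membered aromatic ring of carbon only has the lowest number. Nothing available explains why this exchange lowers the number so much.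

With only one six-membered ring among the compounds shown, the ring itself and its methoxy group cannot be told apart as the source of the step. A plain phenyl group would separate the two, and a 4-hydroxyphenyl or 4-aminophenyl group at the same carbonyl carbon would show whether the methoxy group can be exchanged without losing the gain.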